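A Benzylsulfanyl Group Replaces the Methoxypropoxy Chain

The source may report more compounds than this note shows. Statements on the series, on what has been measured and on what is new or still open speak of the compounds shown alone.

Three compounds of one shared core have been measured in an assay on cells for antagonist activity at transient receptor potential cation channel subfamily V member 1 (Homo sapiens), read by FLIPR and calcium flux, with a stated time of 6 min; a lower number here means a stronger inhibitor, a higher number a weaker inhibitor:

Compound 1 `CCCN(CCC)c1nc(C(C)(C)C)ccc1CNC(=O)C(C)c1ccc(NS(C)(=O)=O)c(F)c1` gives 2.5 nM.
Compound 2 `CCCCCCOc1nc(C(C)(C)C)ccc1CNC(=O)C(C)c1ccc(NS(C)(=O)=O)c(F)c1` gives 2.7 nM.
Compound 3 `COCCCOc1nc(C(C)(C)C)ccc1CNC(=O)C(C)c1ccc(NS(C)(=O)=O)c(F)c1` gives 5.6 nM.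

Compound 3 stands with the highest number of the three. The two steps that reach it are a 2.2-fold higher number from compound 1 to compound 3 (0.35 log units; beyond the scatter) and a 2.1-fold higher number from compound 2 to compound 3 (0.32 log units; beyond the scatter), each modest but beyond the scatter, whereas a 1.1-fold higher number from compound 1 to compound 2 (0.03 log units; within the scatter) lies within it.

Compound 4 `COc1ccc(CSc2nc(C(C)(C)C)ccc2CNC(=O)C(C)c2ccc(NS(C)(=O)=O)c(F)c2)cc1` differs from compound 3 in one place: (4-methoxybenzyl)sulfanyl in place of 3-methoxypropoxy on an aromatic carbon. Among the measured compounds shown here, no measured step exchanges oxygen for sulfur at this aromatic carbon or places an aromatic ring there, so the two steps into compound 3 are the only guide. They show that the two larger groups at this carbon, hexyloxy and dipropylamino, go with lower numbers than the 3-methoxypropoxy chain. The entering group is larger still, so a modest step toward a lower number, or none beyond the scatter, is expected in this assay.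

Compound 4 is therefore estimated at 4 nM, with a range from 1.5 nM to 12 nM, which is expected to mean a 1.4-fold lower number from compound 3 to compound 4 (0.15 log units; within the scatter).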

Compound 4, inhibition constant: 3.5 nM
For compound 4 the middle estimate is 1.1-fold (0.06 log units) above the measured one; the range from low to high includes it.
By their numbers in this assay, from the lowest: compounds 1, 2, 4 and 3 (each within the scatter of the next, the first and the last beyond it).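

At the aromatic carbon next to the ring nitrogen, the shared core carries (4-methoxybenzyl)sulfanyl, with its sulfur and its six-membered aromatic ring of carbon only, and in this assay the three new steps are a 1.6-fold lower number from compound 3 to compound 4 (0.20 log units; within the scatter) and a 1.3-fold higher number from compound 2 to compound 4 (0.11 log units; within the scatter) and a 1.4-fold higher number from compound 1 to compound 4 (0.15 log units; within the scatter) with all of them lying within the scatter. Compound 4 thus cannot be told apart from any of the three earlier compounds, although compound 3 stands apart from compound 1 and from compound 2 by steps beyond the scatter. No evidence on hand bears on this result. On these data alone, the change swaps the atom on the aromatic carbon and brings in the aromatic ring together, so the share of each stays open. A benzyloxy group, a hexylsulfanyl group or an unsubstituted benzylsulfanyl group would separate the two, and a carboxylic acid or an amine at the end of the chain is also absent from the compounds shown.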